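This account rests on a few compounds, and the source may have more. Where it says the series, first, only, none or still open, it means among the compounds named here.

Compound 1 `NC1CCC(Nc2nc(NCc3ccc(-c4ccsc4)cc3)c3ncn(C4CCCC4)c3n2)CC1` gives 120 nM
Compound 2 `NC1CCC(Nc2nc(NCc3ccc(-n4cccn4)cc3)c3ncn(C4CCCC4)c3n2)CC1` gives 103 nM
Compound 3 `NC1CCC(Nc2nc(NCc3ccc(-c4cccc(F)c4)nc3)c3ncn(C4CCCC4)c3n2)CC1` gives 44 nM

In a functional assay on HOS cells (Homo sapiens) for inhibition, with a stated time of 72 h (a lower number here means a stronger inhibitor, a higher number a weaker inhibitor), compound 3 stands lowest of the three, and its gap to each of the other two lies beyond the scatter. In compound 4 `NC1CCC(Nc2nc(NCc3ccc(-c4ccco4)nc3)c3ncn(C4CCCC4)c3n2)CC1`, furan-2-yl takes the place of 3-fluorophenyl on an aromatic carbon, next to the ring nitrogen and para to a large group furan-2-yl in place of 3-fluorophenyl on an aromatic carbon and the rest of the structure stays the same.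

Among the compounds with values here, only one measured step bears on this change: a 1.2-fold lower number from compound 1 to compound 2 (0.07 log units; within the scatter), which also swaps one aromatic group for another. However, compound 1 and compound 2 lack that ring nitrogen, and no measured compound carries furan-2-yl, so the evidence is thin. A shift beyond the scatter is therefore not expected in this assay, though a slightly higher number is the likelier direction. The expected change is a 1.4-fold higher number from compound 3 to compound 4 (0.13 log units; within the scatter), which stays within the scatter. For compound 4 the estimated value is 60 nM, with an expected range from 25 nM to 140 nM in this measurement.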

Compound 4, half-maximal inhibitory concentration: 44 nM
Compound 4: the middle estimate sits 1.4-fold (0.13 log units) above what was measured, and the stated range covers the measured number.
By their numbers in this assay, from the lowest: compounds 3 and 4 (each within the scatter of the next); then compounds 2 and 1 (each within the scatter of the next).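

In this assay there is no change at the digits printed from compound 3 to compound 4 (within the scatter) when furan-2-yl replaces 3-fluorophenyl on this aromatic carbon next to the ring nitrogen, so a five-membered aromatic ring with 1 hetero atom does as well here as a six-membered aromatic ring of carbon only. Putting the whole 6-(furan-2-yl)pyridin-3-yl group in place of 4-(1H-pyrazol-1-yl)phenyl gives a 2.3-fold lower number from compound 2 to compound 4 (0.37 log units; beyond the scatter) and putting it in place of 4-(thiophen-3-yl)phenyl gives a 2.7-fold lower number from compound 1 to compound 4 (0.44 log units; beyond the scatter) and so the low number of compound 3 is not tied to its 3-fluorophenyl group. No measurement offered here explains these results.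

Whether the ring nitrogen alone accounts for those two steps stays open, since each step also changes the outer ring. The compounds shown also leave open how a non-aromatic ring such as morpholine, or an amine or a carboxylic acid, would fare on this carbon.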